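The source may hold more compounds than are shown below. What is called first, only, known or untested is meant among the compounds shown, and "the series" means these compounds.

Three compounds have been measured in an assay on IMR-32 cells for inhibition of Voltage-dependent N-type calcium channel subunit alpha-1B (Homo sapiens); a lower number here means a stronger inhibitor, a higher number a weaker inhibitor:
compound 1, `CC(C)(C)OC(=O)N1CSC[C@H]1C(=O)N[C@@H](CSCC1CCCCC1)C(=O)NCc1ccc(Oc2ccccc2)cc1`, gives 140 nM
compound 2, `CC(C)(C)OC(=O)N1CSC[C@H]1C(=O)N[C@@H](CSCC1CCCCC1)C(=O)NCCNCc1ccccc1`, gives 380 nM
compound 3, `CC(C)(C)OC(=O)N1CSC[C@H]1C(=O)N[C@@H](CSCC1CCCCC1)C(=O)N1CCN(Cc2ccccc2)CC1`, gives 370 nM

Compound 3 stands at the second highest of these three numbers. Its value and that of compound 2 lie within the usual scatter of each other, so nothing separates them. Compound 1 sits at a lower number, and that gap is beyond the scatter.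

Compound 4, `CC(C)(C)OC(=O)N1CSC[C@H]1C(=O)N[C@@H](CSCC1CCCCC1)C(=O)N1CCN(c2ccccc2)CC1`, differs from compound 3 in one place: phenyl in place of benzyl on an amine nitrogen in a ring. Among the compounds with values here, no measured pair shows this same change, so there is no measured step to lean on. The expected step, a 1.2-fold higher number from compound 3 to compound 4 (0.09 log units; within the scatter), is modest, toward a higher number, and probably not beyond the scatter. Compound 4 is estimated at 450 nM, with a range from 150 nM to 1300 nM.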

Compound 4, half-maximal inhibitory concentration: 390 nM
Estimate against measurement, compound 4: 1.2-fold (0.06 log units) above; the range from low to high includes it.
By their numbers in this assay, from the lowest: compound 1; then compounds 3, 2 and 4 (each within the scatter of the next).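

In this assay, phenyl in place of benzyl on the ring amine nitrogen gives a 1.1-fold higher number from compound 3 to compound 4 (0.02 log units; within the scatter), so this change at this position leaves the number unchanged within the scatter. Placing 4-phenylpiperazin-1-yl instead of (2-(benzylamino)ethyl)amino on the carbonyl carbon gives a 1.0-fold higher number from compound 2 to compound 4 (0.01 log units; within the scatter), again with nothing separating the two compounds. No evidence available here bears on this result.

The compounds shown leave open whether a longer chain on that nitrogen, such as 2-phenylethyl, would change the number. They also leave open what a pyridine ring in place of the phenyl would do.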